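Aryl exchange from compound 3 to compound 4: outlook

The source may report more compounds than this note shows. Statements on the series, on what has been measured and on what is new or still open speak of the compounds shown alone.

Measured so far in an assay on CHO cells for displacement of a labelled ligand from adenosine receptor A3 (Homo sapiens), read by scintillation counting, tested at 10 uM; a higher number here means more inhibition at the concentration tested (going by the name of the read-out), a lower number less inhibition:
compound 1 `CC(C)Cc1csc(N)c1C(=O)c1ccc(Cl)cc1`, 1%
compound 2 `Cc1c(-c2ccccc2)sc(N)c1C(=O)c1ccc(Cl)cc1`, 1%
compound 3 `CC(C)(C)Cc1c(-c2cccc(F)c2F)sc(N)c1C(=O)c1ccc(Cl)cc1`, 1%

In this assay compound 1 gives 1%, compound 2 gives 1% and compound 3 gives 1%. Compound 3 stands level with compounds 1 and 2 at the digits reported; its nearest neighbour on the numbers is compound 1, with no change within the scatter, and its furthest is compound 2, again with no change within the scatter. Going by the values given here, no pair of measured compounds differs in a single place, so no step of known size is available from this set, and the three values together say only that the whole group sits at the same low level of inhibition.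

Compound 4 `CC(C)c1ccc(-c2sc(N)c(C(=O)c3ccc(Cl)cc3)c2CC(C)(C)C)cc1` is the next to be measured. Its difference from compound 3: 4-isopropylphenyl in place of 2,3-difluorophenyl on an aromatic carbon.

Given that compound 3, compound 1 and compound 2 all sit at the same low reading with nothing between them beyond the scatter, the step from compound 3 to compound 4 is expected to be none beyond the scatter, a number 1 percentage points higher from compound 3 to compound 4 (within the scatter). Compound 4 is accordingly estimated at 2% in this assay, with a range of -8% to 14%.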

Compound 4, a percentage reported as inhibition, at one concentration (the size of the read-out at that concentration, not a potency): 1%
The estimate for compound 4 lay 1 percentage points above the measured number, within the range that was stated.
By their numbers in this assay, from the lowest: compounds 1, 2, 3 and 4 (each within the scatter of the next).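

In this assay, going by these compounds alone, 4-isopropylphenyl in place of 2,3-difluorophenyl on the aromatic carbon next to the ring sulfur gives no change at the digits printed from compound 3 to compound 4 (within the scatter), the first step of known size. At this position, next to the ring atom that bears a neopentyl group, the fluorinated phenyl and the larger isopropyl-bearing phenyl therefore read alike, though neither group carries a hydrogen-bond donor or acceptor, and the step stays at the same low level as the rest of the group, so it gives no sign of what this position can do when inhibition is higher. Nothing available bears on why the reading stays flat across this change.

Still open, going by these compounds, is whether a phenyl ring carrying an amine or a carboxylic acid at this position would move the reading at all, since both aryl groups compared here are built from carbon and halogen or carbon alone. Also open, on these data alone, is whether a longer chain in place of the neopentyl group, or an amide on the ring amino group, would lift the series enough for this aryl exchange to show a step beyond the scatter.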